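This account rests on a few compounds, and the source may have more. Where it says the series, first, only, none or still open, it means among the compounds named here.

Compound 1 `COC(=O)N1CCCc2cc(S(=O)(=O)N3CC(c4ccccc4)NC3=O)ccc21` gives 4020 nM.
Compound 2 `CC(C)COC(=O)N1CCCc2cc(S(=O)(=O)N3CC(c4ccccc4)NC3=O)ccc21` gives 3720 nM.
Compound 3 `C=CCOC(=O)N1CCCc2cc(S(=O)(=O)N3CC(c4ccccc4)NC3=O)ccc21` gives 6590 nM.

In a functional assay on COLO 205 cells (Homo sapiens) for antiproliferative activity, read by MTT assay (on this read-out higher numbers stand for weaker inhibition and lower numbers for stronger inhibition), compound 2 shows the lowest of the three numbers, yet a 1.1-fold lower number from compound 1 to compound 2 (0.03 log units; within the scatter) and a 1.8-fold higher number from compound 2 to compound 3 (0.25 log units; within the scatter) both lie within the scatter, so no order among the three can be claimed. Compound 4 `O=C1NC(c2ccccc2)CN1S(=O)(=O)c1ccc2c(c1)CCCN2C(=O)C(F)(F)F` differs from compound 2 in one place: trifluoromethyl in place of isobutoxy on a carbonyl carbon. Among the compounds with values here, no measured step tests this exchange; the three known steps, including a 1.6-fold higher number from compound 1 to compound 3 (0.21 log units; within the scatter), only swap the group on the saturated chain carbon bound to an oxygen next to a carbonyl group, and each stayed within the scatter. With the whole chain removed and an uncharged group put on the carbonyl carbon, the data give no basis to expect a shift beyond the scatter. Compound 4 is therefore estimated at 4000 nM (range 1500 nM to 11000 nM), an expected step of a 1.1-fold higher number from compound 2 to compound 4 (0.03 log units; within the scatter).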

Compound 4, half-maximal inhibitory concentration: 10700 nM
Compound 4: the middle estimate sits 2.7-fold (0.43 log units) below what was measured; low and high end bracket the measured number.
By their numbers in this assay, from the lowest: compounds 2, 1, 3 and 4 (each within the scatter of the next, the first and the last beyond it).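

In this assay, the group on this carbonyl carbon can shift the number beyond the scatter, which no swap within the earlier chains did: trifluoromethyl in place of isobutoxy gives a 2.9-fold higher number from compound 2 to compound 4 (0.46 log units; beyond the scatter) and trifluoromethyl in place of methoxy gives a 2.7-fold higher number from compound 1 to compound 4 (0.43 log units; beyond the scatter), both modest. Allyloxy goes against this, as its exchange gives a 1.6-fold higher number from compound 3 to compound 4 (0.21 log units; within the scatter) and so separates nothing. Nothing available explains the shift.

The compounds shown leave open whether the change follows from losing the oxygen-linked chain or from trifluoromethyl itself. A methyl group or an amine on this carbonyl carbon could help separate the two.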